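Swapping a Benzothiophene for a Naphthalene at the Amide

This account rests on a few compounds, and the source may have more. Where it says the series, first, only, none or still open, it means among the compounds named here.

Among the compounds with values here, compound 2 `N=C(N)NCCC[C@@H](NC(=O)c1csc2ccccc12)C(=O)NCc1ccc(C(F)(F)F)cc1` is one of two compounds measured in a functional assay on HEK293 cells for antagonist activity at melanin-concentrating hormone receptor 1 (Homo sapiens) (on this read-out lower numbers stand for stronger inhibition and higher numbers for weaker inhibition), where compound 2 gives 952 nM. Within the data shown here, this is the higher of the two numbers; its only neighbour, compound 1 `COc1ccc2[nH]c(C(=O)N[C@H](CCCNC(=N)N)C(=O)NCc3ccc(C(F)(F)F)cc3)cc2c1`, gives 78 nM in this assay. Among the measured compounds shown here, the single step between them, a 12-fold higher number from compound 1 to compound 2 (1.09 log units; beyond the scatter), is a large move toward weaker inhibition. Compound 3 `N=C(N)NCCC[C@@H](NC(=O)c1ccc2ccccc2c1)C(=O)NCc1ccc(C(F)(F)F)cc1` has not yet been measured. It differs from compound 2 in one place: naphthalen-2-yl in place of 1-benzothiophen-3-yl on a carbonyl carbon. For the measured compounds named here, no measured step covers this exact exchange. Going by the values given here, the only step that bears on it, a 12-fold higher number from compound 1 to compound 2 (1.09 log units; beyond the scatter), shows that changing the aromatic group on this carbonyl carbon can shift this assay a great deal, yet it gives no direction for a naphthalen-2-yl group in particular. With nothing else to lean on, the step is expected to be a 1.3-fold higher number from compound 2 to compound 3 (0.10 log units; within the scatter), which amounts to no change beyond the scatter, though the uncertainty is wide. Compound 3 is therefore estimated at 1200 nM, in a range from 250 nM to 6000 nM.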

Compound 3, half-maximal inhibitory concentration: 212 nM
The estimate for compound 3 lay 5.7-fold (0.75 log units) above the measured number; measured number outside the range, below it.
By their numbers in this assay, from the lowest: compound 1; then compound 3; then compound 2.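

In this assay, the exchange of 1-benzothiophen-3-yl for naphthalen-2-yl on this carbonyl carbon gives a 4.5-fold lower number from compound 2 to compound 3 (0.65 log units; beyond the scatter) and so recovers part of the loss seen with compound 2, which shows that this position separates even two aromatic groups with two rings each. The 5-methoxy-1H-indol-2-yl group still gives the lowest number of the three, for naphthalen-2-yl in its place gives a 2.7-fold higher number from compound 1 to compound 3 (0.43 log units; beyond the scatter) and stays on the weaker side, so the new group does not fully match compound 1. Nothing measured on these compounds accounts for this order.

Within the data shown here, it remains open whether the gain comes from the six-membered ring of carbon only that replaces the sulfur-containing ring or from the different point of attachment, and a naphthalen-1-yl group on the same carbonyl carbon would help to separate the two. From the compounds shown here alone, all three compounds also share the rest of their structure, so it is unknown whether the same order would hold with a simple amine in place of the guanidine at the end of the chain.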